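The compounds below may be only part of what the source reports. "The series", "measured", "known", "first", "only" and "open" are said of these compounds alone.

Going by the values given here, compound 1 `C/C=C/C(=O)Nc1cccc(Oc2nc(Nc3cccc(OC)c3)nc3ccsc23)c1` is the one member of the series with a number in an ADME assay on L02 cells (Homo sapiens) for inhibition, read by MTT assay, with a stated time of 72 h; a lower number here means a stronger inhibitor, a higher number a weaker inhibitor; in this assay compound 1 gives 46000 nM. Compound 2 `COc1cccc(Nc2nc(Oc3cccc(NC(=O)C=C(C)C)c3)c3sccc3n2)c1` belongs to the same series, and in this assay compound 2 gives "not determined" (no result reported). Compound 3 `COc1cccc(Nc2nc(Oc3cccc(NC(=O)/C=C/C(C)C)c3)c3sccc3n2)c1` likewise belongs to the series, and in this assay compound 3 gives "not determined" (no result reported); so compound 3 stands without a number of its own, and nothing can be said of how it compares with compound 1. The step to compound 4 `CC(C)/C=C/C(=O)Nc1cccc(Oc2nc(Nc3cccc(C#N)c3)nc3ccsc23)c1` is cyano in place of methoxy on an aromatic carbon. Among the compounds with values here, no measured pair shows the same change, so neither the size nor the direction of the step in this assay can be read from the data; no shift beyond the usual scatter is assumed either way. On that basis compound 4 is expected to come out near 40000 nM in this assay, with a range from 15000 nM to 100000 nM.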

Compound 4, half-maximal inhibitory concentration: > 50000 nM
Compound 4: only a limit was reported; the forecaster's own chance of this, stated with the estimate: 30%; middle value at least 1.2-fold (0.09 log units) away from the limit.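

In this assay compound 4 gives > 50000 nM, which is a limit and not a number, so no step can be read between compound 3 and compound 4. The compounds shown leave open how cyano in place of methoxy shifts the value.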